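A new amide substituent in a histone acetyltransferase inhibitor series

A few compounds are considered here, and "the series" means these few. Any claim that something is new, unique, unknown or untested is made for them only; others in the source may bear on it.

Of the compounds shown here, three of one series have been tested in an assay on isolated protein for inhibition of histone acetyltransferase p300 (Homo sapiens), with a stated time of 60 min; on this read-out lower numbers stand for stronger inhibition and higher numbers for weaker inhibition. Compound 1 `COc1ccc(NC(=O)[C@H]2CCCCN2C(=O)C2(c3ccc(Cl)cc3)CCCC2)cc1` gives 5.01 nM in this assay, compound 2 `COc1ccc(NC(=O)[C@H]2CCCN2C(=O)C2(c3ccc(Cl)cc3)CCCC2)cc1` gives 7.94 nM, and compound 3 `COc1ccc(NC(=O)[C@H]2CCCN2C(=O)C2(c3cccc(Cl)c3)CCCC2)nc1` gives 2 nM. Compound 3 therefore stands lowest of the three numbers: its nearest neighbour is compound 1, whose number is higher by a margin beyond the usual scatter, and compound 2 lies further away still, also beyond the scatter.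

The next compound, compound 4 `CNC(=O)c1cccc(NC(=O)[C@H]2CCCN2C(=O)C2(c3cccc(Cl)c3)CCCC2)c1`, has not yet been measured. It differs from compound 3 in a single place: 3-(methylcarbamoyl)phenyl in place of 5-methoxypyridin-2-yl on an amide-type nitrogen. Within the data shown here, no pair of measured compounds shows this change, so nothing measured tells its size. Since the group that enters keeps a ring of similar size on the same amide-type nitrogen, a modest shift is anticipated rather than a large one. For compound 4 the expected step is a 2.0-fold higher number from compound 3 to compound 4 (0.30 log units; within the scatter), which would not clearly exceed the scatter. Compound 4 is therefore estimated at 4 nM in this assay, within a range from 1 nM to 16 nM.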

Compound 4, half-maximal inhibitory concentration: 1260 nM
Compound 4: middle estimate off by 320-fold (2.50 log units), on the low side; measured number outside the range, above it.
By their numbers in this assay, from the lowest: compound 3; then compounds 1 and 2 (each within the scatter of the next); then compound 4.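

In this assay, the substituent on this amide-type nitrogen proves decisive: 3-(methylcarbamoyl)phenyl in place of 5-methoxypyridin-2-yl gives a 630-fold higher number from compound 3 to compound 4 (2.80 log units; beyond the scatter), a large step. The earlier compounds shown here offered no step at this position, so only now is it seen that an incoming group with a six-membered aromatic ring does not by itself preserve the low numbers of this series. Nothing available bears on why the step is so large.

The change alters the ring and its substituent together, so the compounds shown cannot separate the loss of the ring nitrogen from the arrival of the methylcarbamoyl group. They also leave open how a plain phenyl, or a methyl ester in place of the methylcarbamoyl group, would read in this assay.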